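Replacing a tetrazolyl group with a carboxy group

This account rests on a few compounds, and the source may have more. Where it says the series, first, only, none or still open, it means among the compounds named here.

compound 1 `C[C@H](Oc1ccc2ncc(CCC(=O)O)c(C3CC3)c2c1)c1c(Cl)ccc(F)c1Cl` gives 4.1
compound 2 `C[C@H](Oc1ccc2ncc(/C=C/C(=O)O)cc2c1)c1c(Cl)ccc(F)c1Cl` gives 2.5
compound 3 `C[C@H](Oc1ccc2ncc(/C=C/c3nn[nH]n3)c(C3CC3)c2c1)c1c(Cl)ccc(F)c1Cl` gives 3.7

All three were measured in a physicochemical assay for lipophilicity, using the shake flask method (a higher number here means a more lipophilic compound, a lower number a more polar compound), and compound 3 is the second highest, sitting under compound 1 and over compound 2.

Compound 4 `C[C@H](Oc1ccc2ncc(/C=C/C(=O)O)c(C3CC3)c2c1)c1c(Cl)ccc(F)c1Cl` is still unmeasured. It differs from compound 3 by carboxy in place of 2H-tetrazol-5-yl on a double-bonded chain carbon bound to a double-bonded chain carbon in one place: carboxy in place of 2H-tetrazol-5-yl on a double-bonded chain carbon bound to a double-bonded chain carbon.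

For the measured compounds named here, one measured step bears on this, a number 0.40 log units lower from compound 1 to compound 3 (beyond the scatter) as 2-(2H-tetrazol-5-yl)ethenyl replaces 2-carboxyethyl, and it is modest. Read backwards, it hints at a small rise. Compound 2 also carries the 2-carboxyethenyl group, but on a different core, and its 2.5 hints at a fall. These two hints roughly cancel, so no step beyond the scatter is expected in this assay and the estimated move is a number 0.10 log units lower from compound 3 to compound 4 (within the scatter) at most a small one. For compound 4 the expected value is 3.6 and the expected range runs from 3.1 to 4.1 as an estimate only.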

Compound 4, distribution coefficient: 4.1
Estimate against measurement, compound 4: 0.50 log units below, within the range that was stated.
By their numbers in this assay, from the lowest: compound 2; then compound 3; then compounds 1 and 4 (each within the scatter of the next).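

In this assay, the swap at this place can now be read on its own, on a double-bonded chain carbon bound to a double-bonded chain carbon with the rest of the molecule unchanged: carboxy in place of 2H-tetrazol-5-yl gives a number 0.40 log units higher from compound 3 to compound 4 (beyond the scatter). Cyclopropyl in place of hydrogen on an aromatic carbon gives the largest step in the set, a number 1.60 log units higher from compound 2 to compound 4 (beyond the scatter), so this group outweighs the swap of acid-bearing groups on the chain. Changing 2-carboxyethyl to 2-carboxyethenyl gives no change at the digits printed from compound 1 to compound 4 (within the scatter), so in this set the double bond in the chain leaves the number unchanged.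

Nothing measured here explains why any of these numbers move. Also open, going by these compounds, is how an amide or a longer chain in place of carboxy would read on this core.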